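A few compounds are considered here, and "the series" means these few. Any claim that something is new, unique, unknown or untested is made for them only; others in the source may bear on it.

Measured compounds:
- Compound 1, `COc1ccc2[nH]c(C(=O)N3CC(=O)N(Cc4ccccc4)[C@@H](CCc4ccccc4)C3)cc2c1`, in a physicochemical assay for solubility, read by spectrophotometry, in phosphate buffer, with a stated time of 2 h, at pH 7.4; on this read-out higher numbers stand for higher solubility and lower numbers for lower solubility: 4400 nM
- Compound 2, `Cc1ccc2[nH]c(C(=O)N3CC(=O)N(Cc4ccccc4)[C@@H](CN4CCC5(CCC5)CC4)C3)cc2c1`, in this assay: 12300 nM
- Compound 3, `O=C(c1cc2cc(C3CC3)ccc2[nH]1)N1CC(=O)N(Cc2ccccc2)[C@@H](CN2CCN(Cc3ccccc3)CC2)C1`, in this assay: 12900 nM

Compound 1 has the lowest of the three numbers in this assay. Compound 2 and compound 3 both give higher numbers, and both gaps lie beyond the usual scatter of this measurement, so compound 1 is genuinely the least soluble of the three measured compounds.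

Compound 4, `COc1ccc2[nH]c(C(=O)N3CC(=O)N(Cc4ccccc4)[C@@H](CN4[C@H](C)COC[C@@H]4C)C3)cc2c1`, has not yet been measured. It differs from compound 1 in one place: 3,5-dimethylmorpholin-4-yl in place of benzyl on a saturated chain carbon bound to a saturated ring carbon. Within the data shown here, no pair of measured compounds isolates this particular exchange, so its effect cannot be read from a measured step.

Compound 4 is still expected to give a higher number than compound 1 in this assay, because compound 2 gives 12300 nM and compound 3 gives 12900 nM, both well above the number of compound 1. The step from compound 1 to compound 4 is estimated at a 3.0-fold higher number from compound 1 to compound 4 (0.47 log units; beyond the scatter), that is, expected to exceed the scatter in the direction of higher solubility. On that basis compound 4 is expected to reach about 13000 nM, with a likely range from 5000 nM to 35000 nM.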

Compound 4, solubility: > 100000 nM
Compound 4: a limit, no number; the forecaster's own chance of this, stated with the estimate: 5%; middle value at least 7.6-fold (0.88 log units) from the limit.
By their numbers in this assay, from the lowest: compound 1; then compounds 2 and 3 (each within the scatter of the next). At a limit, above all of these: compound 4.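

In this assay compound 4 gives > 100000 nM, which is a limit of the assay and not a number. Exchanging benzyl for 3,5-dimethylmorpholin-4-yl on a saturated chain carbon bound to a saturated ring carbon gives an at least 22-fold higher number from compound 1 to compound 4 (1.35 log units; beyond the scatter), a large step and the first one measured at this place, so what sits here can move the read-out far while the rest of the molecule stays the same. The true size of the step stays unknown, and this single pair gives only its lower bound: the limit of > 100000 nM in this assay, at which 1 of the 4 values shown sits.

The compounds shown leave open which part of the new group goes with the step, whether the ring oxygen, the ring nitrogen or the two methyl groups, and a plain morpholin-4-yl or a cyclohexyl on the same carbon would begin to separate these parts. As far as these compounds go, it also remains open whether the two defined stereocentres of the new group matter, and whether a quite different group at this place, such as a carboxylic acid, would give a step of similar size.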